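A few compounds are considered here, and "the series" means these few. Any claim that something is new, unique, unknown or untested is made for them only; others in the source may bear on it.

Values in a functional assay on SW480 cells (Homo sapiens) for cytotoxicity, read by MTT assay, with a stated time of 48 h; a higher number here means a weaker inhibitor, a lower number a stronger inhibitor:
- compound 1 `CCOC(=O)[C@@]1(C(=O)Nc2ccccc2)C[C@@H]1c1cc(OC)c(OC)c(OC)c1`: > 100000 nM
- compound 2 `CCOC(=O)[C@]1(C(=O)Nc2ccccc2)C[C@@H]1c1cc(OC)c(OC)c(OC)c1`: 31700 nM
- compound 3 `CCOC(=O)C1(C(=O)Nc2ccccc2Cl)CC1c1cc(OC)c(OC)c(OC)c1`: 27200 nM; 66700 nM (2 entries)

Compound 1 stands at > 100000 nM, which is a limit and not a number. Compound 4 `CCOC(=O)[C@@]1(C(=O)Nc2ccccc2Cl)C[C@@H]1c1cc(OC)c(OC)c(OC)c1` keeps the configuration of compound 1 as drawn and makes one change: chloro in place of hydrogen on an aromatic carbon, taking phenyl to 2-chlorophenyl. For the measured compounds named here, no measured step isolates this change. The closest evidence is compound 3, which carries the same 2-chlorophenyl group with no configuration drawn, and its record shows (the several entries of compound 3 in this assay, 27200 nM; 66700 nM (2 entries)). Going by the values given here, the only measured step, an at least 3.1-fold lower number from compound 1 to compound 2 (0.49 log units; beyond the scatter), reflects (the fact that compounds 1 and 2 differ only in the configuration as drawn), and there the configuration of compound 1 is the weaker one. Compound 4 therefore has the chloro group of compound 3 but the less favourable configuration of that pair, so a modest move toward a lower number is expected in this assay, and another limit would be no surprise. The expected change is an at least 1.4-fold lower number from compound 1 to compound 4 (0.15 log units; that floor lies within the scatter). For compound 4 the estimated value is 70000 nM, with an expected range from 30000 nM to 150000 nM.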

Compound 4, half-maximal inhibitory concentration: 46700 nM
Beside the measured number, compound 4's estimate is 1.5-fold (0.18 log units) above it; measured number inside the range.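

In this assay, chloro in place of hydrogen on an aromatic carbon, taking phenyl to 2-chlorophenyl, gives an at least 2.1-fold lower number from compound 1 to compound 4 (0.33 log units; beyond the scatter), the first step shown that concerns this position and not the configuration. Compound 1 stands at > 100000 nM, which is a limit and not a number, so this step gives only a floor for the size of the change. The 2-chlorophenyl group thus brings a measured number to a configuration that stays at a limit with phenyl, while any comparison of compound 4 with compound 3 stays loose: the fact that one of compounds 3 and 4 is drawn with a defined configuration and the other without, at the place where they differ

As far as these compounds go, what the chloro group does in the configuration of compound 2 remains open. So does whether a fluoro, methyl or methoxy group at this place would move the number in the same way.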